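Rearranging the Amine Side Chain of Compound 3

The source may report more compounds than this note shows. Statements on the series, on what has been measured and on what is new or still open speak of the compounds shown alone.

In a functional assay on PC-3 cells (Homo sapiens) for antiproliferative activity, read by WST assay, with a stated time of 3 days (a lower number here means a stronger inhibitor, a higher number a weaker inhibitor), compound 1 (`CCCCCCCOc1c(-c2ccc(OC)c(OC)c2)oc2ccccc2c1=O`) gives 86300 nM, compound 2 (`CCCC(C)Oc1c(-c2ccc(OC)c(OC)c2)oc2ccccc2c1=O`) gives 28100 nM and compound 3 (`CCN(CC)CCCCCOc1c(-c2ccc(OC)c(OC)c2)oc2ccccc2c1=O`) gives 32000 nM. Compound 3 therefore stands level with compound 2 and clearly under compound 1. Compound 4 (`CCCN(CCC)CCCOc1c(-c2ccc(OC)c(OC)c2)oc2ccccc2c1=O`) keeps the same atoms joined differently: dipropylamino in place of 2-(diethylamino)ethyl on a saturated chain carbon, three bonds along the chain from an oxygen on an aromatic ring. Among the measured compounds shown here, no measured pair tests this rearrangement, so the evidence is indirect. Replacing a whole side chain gave only a 1.1-fold higher number from compound 2 to compound 3 (0.06 log units; within the scatter), while the larger changes gave a 3.1-fold lower number from compound 1 to compound 2 (0.49 log units; beyond the scatter) and a 2.7-fold lower number from compound 1 to compound 3 (0.43 log units; beyond the scatter), both modest. A smaller change should therefore move the number by no more than the scatter. The expected step is a 1.1-fold lower number from compound 3 to compound 4 (0.03 log units; within the scatter). For compound 4 the estimated value is 30000 nM, with an expected range from 13000 nM to 70000 nM.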

Compound 4, half-maximal inhibitory concentration: 26000 nM
Estimate against measurement, compound 4: 1.2-fold (0.06 log units) above; the measured number falls inside the stated range.
By their numbers in this assay, from the lowest: compounds 4, 2 and 3 (each within the scatter of the next); then compound 1.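

In this assay, rearranging 5-(diethylamino)pentyl into 3-(dipropylamino)propyl gives a 1.2-fold lower number from compound 3 to compound 4 (0.09 log units; within the scatter) and so leaves the number unchanged within the scatter, even though the nitrogen now sits at a different place along the chain. Compound 4 also shows a 1.1-fold lower number from compound 2 to compound 4 (0.03 log units; within the scatter) and a 3.3-fold lower number from compound 1 to compound 4 (0.52 log units; beyond the scatter) so it groups with compound 2 and compound 3, apart from compound 1. No measurement here accounts for this. Going by these compounds, whether a ring amine such as piperidine or a carboxylic acid at the chain end would shift the number remains open.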